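From 3-Fluorophenyl to 2-Fluoro-3-(trifluoromethyl)phenyl on the Oxygen

This account rests on a few compounds, and the source may have more. Where it says the series, first, only, none or still open, it means among the compounds named here.

Compound 1, `CC(C)[C@H](NC(=O)COc1cccc2ccccc12)C(=O)N[C@@H](CC(=O)O)C(=O)COc1ccccc1C(F)(F)F`, gives 17300 nM in a functional assay with Homo sapiens as the target; on this read-out lower numbers stand for stronger inhibition and higher numbers for weaker inhibition.
Compound 2, `CC(C)[C@H](NC(=O)COc1cccc2ccccc12)C(=O)N[C@@H](CC(=O)O)C(=O)COc1ccc(Oc2ccccc2)cc1`, gives 19000 nM in this assay.
Compound 3, `CC(C)[C@H](NC(=O)COc1cccc2ccccc12)C(=O)N[C@@H](CC(=O)O)C(=O)COc1cccc(F)c1`, gives 12000 nM in this assay.

The three compounds share one core and differ only in the group carried on the oxygen on the saturated carbon. Compound 3 shows the lowest of the three numbers, yet it stands apart from neither neighbour: the step of a 1.4-fold lower number from compound 1 to compound 3 (0.16 log units; within the scatter) lies within the scatter, and the value of compound 2 lies equally close to that of compound 3, so no order among the three can be read from these numbers.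

Compound 4, `CC(C)[C@H](NC(=O)COc1cccc2ccccc12)C(=O)N[C@@H](CC(=O)O)C(=O)COc1cccc(C(F)(F)F)c1F`, is the next member of the set. Its change from compound 3 is 2-fluoro-3-(trifluoromethyl)phenyl in place of 3-fluorophenyl on an oxygen on a saturated carbon. Among the compounds with values here, the one measured step that bears on it is a 1.4-fold lower number from compound 1 to compound 3 (0.16 log units; within the scatter), in which a phenyl bearing a trifluoromethyl and a phenyl bearing a single fluorine gave numbers indistinguishable within the scatter. Compound 4 combines both substituents on one ring, and on that evidence the step is expected to be a 1.2-fold higher number from compound 3 to compound 4 (0.07 log units; within the scatter), with no movement beyond the scatter in either direction. Compound 4 is therefore estimated to give 14000 nM in this assay, within a range from 6000 nM to 35000 nM.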

Compound 4, half-maximal inhibitory concentration: 18200 nM
Beside the measured number, compound 4's estimate is 1.3-fold (0.11 log units) below it; low and high end bracket the measured number.
By their numbers in this assay, from the lowest: compounds 3, 1, 4 and 2 (each within the scatter of the next).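

In this assay, 2-fluoro-3-(trifluoromethyl)phenyl, with 11 heavy atoms, in place of 3-fluorophenyl, with 7, gives a 1.5-fold higher number from compound 3 to compound 4 (0.18 log units; within the scatter) and so does not separate the two groups on this oxygen on a saturated carbon, even though the entering phenyl carries both a fluorine and a trifluoromethyl. The same group in place of 2-(trifluoromethyl)phenyl gives a 1.1-fold higher number from compound 1 to compound 4 (0.02 log units; within the scatter) and so also leaves compound 4 indistinguishable from compound 1, which shows that combining the two substituents on one ring does not produce a step beyond the scatter from either of these neighbours. No measurement of any property of these groups is available to account for this result.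

Every group shown at this position is a phenyl ring of carbon only, so it remains open whether an amine, a carboxylic acid or a longer saturated chain placed on this oxygen would produce a step beyond the scatter. On these data alone, it also remains open whether these groups would stay this close to one another if the shared core carried something other than its naphthalene-free form of the present side chains.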